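Amide aryl swap on the shared core: cytotoxicity notes

The source may report more compounds than this note shows. Statements on the series, on what has been measured and on what is new or still open speak of the compounds shown alone.

Measured so far:
compound 1 `COc1ccc(-c2cnc(NC(=O)c3cccnc3)n2C)cc1` — > 100000 nM
compound 2 `Cc1ccc(C(=O)Nc2ncc(-c3ccccc3)n2C)cc1` — > 50000 nM

In a toxicity assay on THP-1 cells (Homo sapiens) for inhibition (on this read-out higher numbers stand for lower toxicity in this test and lower numbers for higher toxicity in this test), compound 1 gives > 100000 nM, which is a limit of the assay and not a number (the limit of > 100000 nM in this assay, at which 1 of the 2 values shown sits). Compound 2 gives > 50000 nM in this assay, again a limit rather than a number (the limit of > 50000 nM in this assay, at which 1 of the 2 values shown sits). Among the measured compounds shown here, compound 1 therefore stands at the upper limit of what the test reports; neither value shown is a finite number, so no measured step exists.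

Compound 3 `COc1ccc(-c2cnc(NC(=O)c3cccc(OC)c3)n2C)cc1` is the next member. Its change from compound 1 is 3-methoxyphenyl in place of pyridin-3-yl on a carbonyl carbon. With both measured amides sitting at a limit, the expectation for this change in this assay is no step beyond the usual scatter, in either direction. Compound 3 is expected to give 100000 nM, estimated between 30000 nM and 300000 nM. The expected step is a number no higher from compound 1 to compound 3 (the limit leaves the size open), meaning compound 3 is also estimated to reach the limit.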

Compound 3, half-maximal cytotoxic concentration: > 100000 nM
Compound 3 gave a limit, no number; the forecaster's own chance of this, stated with the estimate: 75%; the middle value sits exactly at the limit.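

Among the compounds shown here, compound 1 and compound 3 both give only a limit in this assay, and no step between them can be read. On these data alone, whether 3-methoxyphenyl in place of pyridin-3-yl on a carbonyl carbon changes this read-out at all remains open, as does any finite value for either compound.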